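Swapping the Halophenyl Ether Group on Compound 1

This account rests on a few compounds, and the source may have more. Where it says the series, first, only, none or still open, it means among the compounds named here.

Measured so far:
compound 1, `NC1=NC2(CCOCC2)N(OCCCOc2ccc(Cl)cc2)C(N)=N1`: 690 nM
compound 2, `NC1=NC2(CCSCC2)N(OCCCOc2ccc(Br)cc2)C(N)=N1`: 20 nM

In a functional assay on HCT-116 cells (Homo sapiens) for antiproliferative activity, read by MTT assay, with a stated time of 72 h (on this read-out lower numbers stand for stronger inhibition and higher numbers for weaker inhibition), compound 1 gives 690 nM, the highest of the two numbers in hand. Compound 2 gives 20 nM in this assay, and the gap between compound 2 and compound 1 lies beyond the scatter. Among the compounds with values here, compound 2 differs from compound 1 in more than one place, so no single step links the two, and the gap cannot be assigned to either change.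

Compound 3, `NC1=NC2(CCOCC2)N(OCCCOc2cccc(Br)c2)C(N)=N1`, has not yet been measured. It differs from compound 1 in one place: 3-bromophenyl in place of 4-chlorophenyl on an oxygen on a saturated carbon. Within the data shown here, no step between measured compounds of this kind exists, so the size of this move rests on little. The step of a 1.4-fold lower number from compound 1 to compound 3 (0.14 log units; within the scatter) is expected to be small, toward a lower number, and not clearly beyond the scatter. Compound 3 is therefore expected to give 500 nM in this assay, within a range from 120 nM to 2000 nM.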

Compound 3, half-maximal inhibitory concentration: 40 nM
Compound 3: the middle estimate sits 13-fold (1.10 log units) above what was measured; measured number below the stated range.
By their numbers in this assay, from the lowest: compounds 2 and 3 (each within the scatter of the next); then compound 1.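

The step shows that the aryl end of the ether matters a great deal in this assay: with the core of compound 1 left unchanged, 3-bromophenyl in place of 4-chlorophenyl on an oxygen on a saturated carbon gives a 17-fold lower number from compound 1 to compound 3 (1.24 log units; beyond the scatter), a large step beyond the scatter. The two groups have the same count of heavy atoms and of hydrogen-bond donors and acceptors, so those counts do not tell them apart. Nothing at hand bears on why this change has so large an effect.

The halogen and its ring position change together in this one step, so the compounds shown cannot say which of the two carries it. As far as these compounds go, whether 3-chlorophenyl or plain phenyl in this place would keep the lower number remains open.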